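This account rests on a few compounds, and the source may have more. Where it says the series, first, only, none or still open, it means among the compounds named here.

Measured so far in an ADME assay on HFF cells (Homo sapiens) for cytotoxicity, with a stated time of 8 days; a lower number here means that less compound is tolerated, a higher number that more compound is tolerated:
compound 1 `CNc1nc(N)nc2c1ncn2/C=C1/CC1(CO)CO` gives 265000 nM
compound 2 `CN(C)c1nc(N)nc2c1ncn2/C=C1/CC1(CO)CO` gives > 300000 nM, which is a limit of the assay, not a number
compound 3 `CC(C)CNc1nc(N)nc2c1ncn2/C=C1/CC1(CO)CO` gives > 300000 nM, again a limit of the assay

Compound 2 therefore stands at the top of what this assay reports; (the limit of > 300000 nM in this assay, at which 2 of the 3 values shown sit). The next compound, compound 4 `CCCCSc1nc(N)nc2c1ncn2/C=C1/CC1(CO)CO`, differs from compound 2 by butylsulfanyl in place of dimethylamino on an aromatic carbon. The measured steps give little to go on: an at least 1.1-fold higher number from compound 1 to compound 2 (0.05 log units; that floor lies within the scatter) and an at least 1.1-fold higher number from compound 1 to compound 3 (0.05 log units; that floor lies within the scatter) are only floors, and a step that the two limits leave unreadable from compound 2 to compound 3. Nothing here points to a step beyond the scatter in this assay, in either direction, so the step of a number no higher from compound 2 to compound 4 (the limit leaves the size open) is expected to be flat. Compound 4 is estimated at 300000 nM, with a range of 150000 nM to 600000 nM, most likely reported again only as a limit.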

Compound 4, half-maximal cytotoxic concentration: > 300000 nM
Compound 4: a limit, no number (the forecaster's own chance of this, stated with the estimate: 65%); the middle value sits exactly at the limit.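

The position is no longer shown only with nitrogen-linked groups: butylsulfanyl, attached through sulfur, also occupies this aromatic carbon, and compound 4 is reported only as a limit. Methylamino to butylsulfanyl gives an at least 1.1-fold higher number from compound 1 to compound 4 (0.05 log units; that floor lies within the scatter). The steps from compound 2 and compound 3 to compound 4 cannot be read, and in this assay the series crowds at the ceiling: the limit of > 300000 nM in this assay, at which 3 of the 4 values shown sit.

Still open, on these data alone, is whether any group here, such as a carboxylic acid or a phenylsulfanyl, brings a value below that limit. Butylamino would separate the sulfur link from the chain.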